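A few compounds are considered here, and "the series" means these few. Any claim that something is new, unique, unknown or untested is made for them only; others in the source may bear on it.

Three compounds have been measured in a functional assay on Shh Light II cells (Mus musculus) for inhibition, read by a luciferase reporter; a higher number here means a weaker inhibitor, a lower number a stronger inhibitor:

Compound 1 `COc1ccccc1NC(=O)N1CCC(c2nc(-c3ccc4ccccc4n3)no2)CC1` gives 410 nM.
Compound 2 `O=C(Nc1ncccc1Cl)N1CCC(c2nc(-c3ccc4ccccc4n3)no2)CC1` gives 2800 nM.
Compound 3 `O=C(Nc1cccnc1Cl)N1CCC(c2nc(-c3ccc4ccccc4n3)no2)CC1` gives 1600 nM.

All three share the same core and differ only in the group on the amide-type nitrogen. Compound 3 sits among the two higher numbers of the three: its value and that of compound 2 lie within the usual scatter of each other, as a 1.8-fold lower number from compound 2 to compound 3 (0.24 log units; within the scatter) shows, while compound 1 is well separated, since a 3.9-fold higher number from compound 1 to compound 3 (0.59 log units; beyond the scatter) is a step beyond the scatter.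

Compound 4 `O=C(NC1CCOCC1)N1CCC(c2nc(-c3ccc4ccccc4n3)no2)CC1` is the next compound, not yet measured. Its change from compound 3 is oxan-4-yl in place of 2-chloropyridin-3-yl on an amide-type nitrogen. An aromatic ring gives way to a non-aromatic one.

The measured steps bear on this only indirectly. a 6.8-fold higher number from compound 1 to compound 2 (0.83 log units; beyond the scatter) and a 3.9-fold higher number from compound 1 to compound 3 (0.59 log units; beyond the scatter) show that swapping one aromatic group for another on this nitrogen shifts the number by modest amounts, and a 1.8-fold lower number from compound 2 to compound 3 (0.24 log units; within the scatter) shows that two closely related aromatic groups can give numbers within the scatter. Within the data shown here, no measured pair exchanges an aromatic ring for a non-aromatic one, so the direction of this step is uncertain. A step of about a 1.9-fold higher number from compound 3 to compound 4 (0.27 log units; within the scatter) is expected, within the scatter but with a wide range. Compound 4 is estimated at 3000 nM, between 800 nM and 12000 nM.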

Compound 4, half-maximal inhibitory concentration: 480 nM
Beside the measured number, compound 4's estimate is 6.3-fold (0.80 log units) above it; measured number below the stated range.
By their numbers in this assay, from the lowest: compounds 1 and 4 (each within the scatter of the next); then compounds 3 and 2 (each within the scatter of the next).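

In this assay this amide-type nitrogen accepts a non-aromatic ring: oxan-4-yl in place of 2-chloropyridin-3-yl gives a 3.3-fold lower number from compound 3 to compound 4 (0.52 log units; beyond the scatter) and in place of 3-chloropyridin-2-yl gives a 5.8-fold lower number from compound 2 to compound 4 (0.77 log units; beyond the scatter) so both chloropyridinyl compounds are separated from compound 4 by more than the scatter. Oxan-4-yl in place of 2-methoxyphenyl gives a 1.2-fold higher number from compound 1 to compound 4 (0.07 log units; within the scatter) so among these four compounds an aromatic ring is not required for a number in the range of compound 1, and aromatic rings as such do not set the level, since compound 1 carries one and compounds 2 and 3 carry one too. No supporting measurement accompanies these numbers that could account for the shift.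

From the compounds shown here alone, whether the ring oxygen of oxan-4-yl matters remains open, and a plain cyclohexyl group or an amine such as piperidin-4-yl on this nitrogen would address that. Also open, going by these compounds, is whether a ring is needed here at all, which an open chain such as 2-methoxyethyl would test.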